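Halogen pattern change on the aryl thiosemicarbazide of compound 2

This account rests on a few compounds, and the source may have more. Where it says the series, first, only, none or still open, it means among the compounds named here.

Compound 1, `O=C1Nc2ccc(F)cc2/C1=N/NC(=S)Nc1cccc(C(F)(F)F)c1`, and compound 2, `O=C1Nc2ccc(F)cc2/C1=N/NC(=S)Nc1cccc(F)c1`, share one core and differ in a single aryl substituent. In a functional assay on the whole organism for inhibition, with Lemna aequinoctialis as the target, with a stated time of 7 days, tested at 500 ug/mL (a higher number here means more inhibition of growth at the concentration tested, a lower number less inhibition of growth), compound 1 gives 30%, and compound 2 gives 30%; the step of no change at the digits printed from compound 1 to compound 2 (within the scatter) lies within the scatter, so compound 2 stands level with compound 1. Compound 3, `O=C1Nc2ccc(F)cc2/C1=N/NC(=S)Nc1ccc(Br)cc1F`, carries 4-bromo-2-fluorophenyl in place of 3-fluorophenyl on an amide-type nitrogen. Within the data shown here, the only measured step touching this aryl group was flat, so the change is expected to bring little, with no change at the digits printed from compound 2 to compound 3 (within the scatter) estimated to stay within the scatter. Compound 3 is therefore expected to give 30%, in a range from 15% to 45%.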

Compound 3, percent growth inhibition at one concentration: 30%
The estimate for compound 3 equals the measured number at the digits printed, and the stated range covers the measured number.
By their numbers in this assay, from the lowest: compounds 1, 2 and 3 (each within the scatter of the next).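

On an amide-type nitrogen whose other neighbour is the thiocarbonyl carbon, the step of no change at the digits printed from compound 2 to compound 3 (within the scatter) shows that 4-bromo-2-fluorophenyl can stand in for 3-fluorophenyl without a readable shift in growth inhibition. The earlier step had only exchanged one substituent for another, whereas this one adds a bromine to the ring, and the read-out still holds level. Nothing available bears on why this position reads so flat.

As far as these compounds go, what an amine or a carboxylic acid on this aryl ring would do remains open. So does whether a longer alkyl chain in place of the ring would move growth inhibition.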